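The compounds below may be only part of what the source reports. "The series", "measured", "known", "first", "only" and "open" are said of these compounds alone.

Measured compounds in a functional assay on HepG2 cells (Homo sapiens) for cytotoxicity, read by MTT assay, with a stated time of 48 h; on this read-out lower numbers stand for stronger inhibition and higher numbers for weaker inhibition:
compound 1 `COc1ccc(CN2C(=O)C(=O)c3cc(/C=C/C(=O)OC(C)(C)C)ccc32)cc1`, 620 nM;
compound 2 `CC(C)(C)OC(=O)/C=C/c1ccc2c(c1)C(=O)C(=O)N2Cc1ccc(Br)cc1`, 2050 nM;
compound 3 `COC(=O)/C=C/c1cccc2c1N(Cc1ccc(OC)cc1)C(=O)C2=O`, which in this assay gives only a limit, > 10000 nM.

Compound 1 holds the lowest of the two numbers that were obtained. Going by the values given here, its nearest neighbour is compound 2, reached by a 3.3-fold higher number from compound 1 to compound 2 (0.52 log units; beyond the scatter); that step, bromo in place of methoxy on an aromatic carbon, is the only single change measured in this set. Compound 3 sits at the limit of > 10000 nM in this assay, at which 1 of the 3 values shown sits, so it contributes no number for comparison.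

Compound 4 `COC(=O)/C=C/c1ccc2c(c1)C(=O)C(=O)N2Cc1ccc(OC)cc1` differs from compound 1 in one place: methyl in place of tert-butyl on an oxygen next to a carbonyl group. No measured step touches the ester; the one step shown concerns the aromatic substituent and so does not bear on this change. Among the compounds with values here, compound 3 also carries a methoxycarbonyl group, but it differs from compound 4 in the attachment of the side chain as well, and no step between them is available.

With nothing to point either way, compound 4 is expected to stay close to compound 1, and the estimated step is a 1.5-fold higher number from compound 1 to compound 4 (0.16 log units; within the scatter). The estimate for compound 4 in this assay is therefore 900 nM, with a range from 350 nM to 2500 nM.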

Compound 4, half-maximal inhibitory concentration: 30 nM
For compound 4 the middle estimate is 30-fold (1.48 log units) above the measured one; the measured number lies below the stated range.
By their numbers in this assay, from the lowest: compound 4; then compound 1; then compound 2. At a limit, above all of these: compound 3.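

In this assay, the group on the oxygen next to a carbonyl group turns out to matter a great deal: methyl in place of tert-butyl gives a 21-fold lower number from compound 1 to compound 4 (1.32 log units; beyond the scatter). Going by these compounds alone, this change outweighs the only earlier single change, bromo in place of methoxy on an aromatic carbon, which gave a 3.3-fold higher number from compound 1 to compound 2 (0.52 log units; beyond the scatter), so the ester end of the molecule moves the number further than that aromatic substituent does. The methoxycarbonyl group alone does not ensure a low number, as compound 3, which also carries it but has the side chain attached differently, gives only a limit: the limit of > 10000 nM in this assay, at which 1 of the 4 values shown sits.

From the compounds shown here alone, only tert-butyl and methyl appear on this oxygen, so it remains open how an ethyl or isopropyl ester would read, or how a free carboxylic acid or an amide would read in place of the ester. Going by these compounds, it is also open whether bromo in place of methoxy would produce a similar step on the methoxycarbonyl series as it does with the tert-butoxycarbonyl group.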